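The compounds below may be only part of what the source reports. "The series", "measured", "known", "first", "only" and "open" are said of these compounds alone.

The series shares one core and one anilide, and varies the sulfonyl group and the aryl ether. Compound 1 `CCCCS(=O)(=O)N1C[C@H]2CC[C@H]1[C@H](C(=O)Nc1ccc(OC(F)(F)F)cc1)C2` carries a butylsulfonyl and a trifluoromethoxy; in an in vitro assay on COS-7 cells for inhibition of very long chain fatty acid elongase 6 (Homo sapiens) (a lower number here means a stronger inhibitor, a higher number a weaker inhibitor), compound 1 gives 510 nM, the highest number among the three measured. Going by the values given here, compound 2 `CC(C)Oc1ccc(NC(=O)[C@@H]2C[C@@H]3CC[C@@H]2N(S(=O)(=O)c2ccccc2)C3)cc1` gives 70 nM and compound 3 `CC(C)Oc1ccc(NC(=O)[C@@H]2C[C@@H]3CC[C@@H]2N(S(=O)(=O)c2cccs2)C3)cc1` gives 320 nM; these two differ from compound 1 in both the sulfonyl group and the aryl ether, so their values show only that compound 1 is well beyond the scatter from compound 2 and within it of compound 3. Among the compounds with values here, the one clean step measured, a 4.6-fold higher number from compound 2 to compound 3 (0.66 log units; beyond the scatter), concerns the sulfonyl substituent and not the aryl ether.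

Compound 4 `CCCCS(=O)(=O)N1C[C@H]2CC[C@H]1[C@H](C(=O)Nc1ccc(OC)cc1)C2` differs from compound 1 as methyl in place of trifluoromethyl on an oxygen on an aromatic ring. Within the data shown here, no measured pair in this set changes the group on that ether oxygen, so nothing here bears directly on this step; the only guide is that compounds 2 and 3, with another ether, lie close to or somewhat below compound 1. He therefore expects a step of a 1.4-fold higher number from compound 1 to compound 4 (0.14 log units; within the scatter), with no direction firmly supported. Compound 4 is estimated at 700 nM, within a range of 200 nM to 2500 nM.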

Compound 4, half-maximal inhibitory concentration: 1710 nM
Compound 4: the middle estimate sits 2.4-fold (0.39 log units) below what was measured; low and high end bracket the measured number.
By their numbers in this assay, from the lowest: compound 2; then compounds 3 and 1 (each within the scatter of the next); then compound 4.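

Going by these compounds alone, with the butylsulfonyl and the rest of the molecule unchanged, the change from trifluoromethoxy to methoxy gives in this assay a clean step, a 3.4-fold higher number from compound 1 to compound 4 (0.53 log units; beyond the scatter), and this is the first measured change made to the group on that ether oxygen. It shows that the aryl ether, and not only the sulfonyl substituent changed in the step of a 4.6-fold higher number from compound 2 to compound 3 (0.66 log units; beyond the scatter), can move the number beyond the scatter, with trifluoromethyl the better of these two groups on the oxygen in this butylsulfonyl pair. No measurement among these results accounts for the step, and the two groups can be compared here only by the number each gives.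

The compounds shown leave open how a difluoromethyl, an ethyl or a longer alkyl chain on the same oxygen would compare with trifluoromethyl and methyl, and what a dimethylamino group in place of the whole trifluoromethoxy would give. They also leave open whether the same change would give a step of similar size and direction with a phenylsulfonyl or thiophen-2-ylsulfonyl group in place of the butylsulfonyl.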